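The source may report more compounds than this note shows. Statements on the series, on what has been measured and on what is new or still open speak of the compounds shown alone.

Working notes on the series. For the measured compounds named here, compound 1 `c1ccc2c(c1)CC2CCCN1CCN(c2cccc3c2OCCO3)CC1` gives 0.45 mg/kg in an assay for activation of Adrenergic receptor alpha-1 (Rattus norvegicus) (a higher number here means that more compound is needed for the effect, a lower number that less compound is needed), the lowest of the three numbers known; compound 3 `c1ccc2c(c1)CCC2CCN1CCN(c2cccc3c2OCCO3)CC1` gives 4.01 mg/kg and compound 2 `c1ccc2c(c1)CCC2CN1CCN(c2cccc3c2OCCO3)CC1` gives 5 mg/kg, and those two are within the scatter of each other. The step from compound 1 to compound 3 is an 8.9-fold higher number from compound 1 to compound 3 (0.95 log units; beyond the scatter). Compound 4 `c1ccc2c(c1)CCC2CCCN1CCN(c2cccc3c2OCCO3)CC1` differs from compound 1 by a group of 9 heavy atoms (9 carbon; one five-membered non-aromatic ring of carbon only, one six-membered aromatic ring of carbon only) in place of a group of 8 heavy atoms (8 carbon; one four-membered non-aromatic ring of carbon only, one six-membered aromatic ring of carbon only), on a saturated chain carbon, three bonds along the chain from an amine nitrogen in a ring, the same ring enlargement as that step, kept on the longer chain. Going by the values given here, since both indanyl compounds measured so far sit at the higher end, the expected step is an upward one, a 5.6-fold higher number from compound 1 to compound 4 (0.74 log units; beyond the scatter), though the chain is different and no measured pair covers this exactly. The estimate for compound 4 is 2.5 mg/kg, within 0.7 mg/kg to 8 mg/kg.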

Compound 4, dose for half-maximal effect: 0.23 mg/kg
Estimate against measurement, compound 4: 11-fold (1.04 log units) above; measured number outside the range, below it.
By their numbers in this assay, from the lowest: compounds 4 and 1 (each within the scatter of the next); then compounds 3 and 2 (each within the scatter of the next).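

On the chain of compound 4, at the place three bonds along the chain from an amine nitrogen in a ring, 2,3-dihydro-1H-inden-1-yl is tolerated in this assay: the change gives a 2.0-fold lower number from compound 1 to compound 4 (0.29 log units; within the scatter). For the compounds shown here, the higher numbers of the earlier compounds therefore do not follow from this group alone, since compound 3 gives 4.01 mg/kg, compound 2 gives 5 mg/kg, and both carry it on a shorter chain. No measurement on hand accounts for this result.

Going by these compounds, whether a longer chain or a hydroxyl group on the 2,3-dihydro-1H-inden-1-yl group would keep the number in this range remains open.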